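Removing the guanidine from a lipidated dipeptide agonist

This account rests on a few compounds, and the source may have more. Where it says the series, first, only, none or still open, it means among the compounds named here.

Compound 2 `CCCCCCCCCCCC(=O)N[C@H](CCC(=O)NC(CCCC(NC(=N)N)C(=O)O)C(=O)O)C(=O)O` gives 0.622 nM in a functional assay on HEK293 cells for agonist activity at Nucleotide-binding oligomerization domain-containing protein 1 (Homo sapiens), read by spectrophotometry (on this read-out higher numbers stand for an effect only at larger amounts of compound and lower numbers for an effect already at smaller amounts), the lowest number of the two measured compounds. Compound 1 `CCCCCCCCCCCC(=O)N[C@H](CCC(=O)NC(CCCC1NC(N)=NC1=O)C(=O)O)C(=O)O` gives 1.31 nM in this assay, and the step of a 2.1-fold lower number from compound 1 to compound 2 (0.32 log units; beyond the scatter) separates them, a change in which an open guanidine replaces a cyclic one. Compound 3 `CCCCCCCCCCCC(=O)N[C@H](CCC(=O)NC(CCCCC(=O)O)C(=O)O)C(=O)O` carries a hydrogen atom in place of a group of 4 heavy atoms (1 carbon, 3 nitrogen; no ring), on a saturated chain carbon bound to a carbonyl carbon and a saturated chain carbon, so the basic group that both measured compounds share is gone altogether. Going by the values given here, only the single step from compound 1 to compound 2 bears on this, and it was modest; no measured step removes the group outright. A larger change in this assay is therefore expected for compound 3, toward higher numbers, with an estimated step of a 96-fold higher number from compound 2 to compound 3 (1.98 log units; beyond the scatter). Compound 3 is expected to give about 60 nM, in a range from 5 nM to 1000 nM, with considerable uncertainty.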

Compound 3, half-maximal effective concentration: > 100 nM
Compound 3 gave a limit, no number; the forecaster's own chance of this, stated with the estimate: 15%; at least 1.6-fold (0.22 log units) between middle value and limit.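

For compound 3 the result in this assay is a limit and not a number: the limit of > 100 nM in this assay, at which 1 of the 3 values shown sits. Taking away the group of 4 heavy atoms (1 carbon, 3 nitrogen; no ring) and leaving a hydrogen atom on the saturated chain carbon bound to a carbonyl carbon and a saturated chain carbon gives an at least 160-fold higher number from compound 2 to compound 3 (2.20 log units; beyond the scatter), far more than the modest 2.1-fold lower number from compound 1 to compound 2 (0.32 log units; beyond the scatter) between the open and cyclic forms. Measured against the cyclic form, the loss is also large, at an at least 76-fold higher number from compound 1 to compound 3 (1.88 log units; beyond the scatter), so at this position the two forms differ little compared with having neither.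

The compounds shown do not tell how far beyond its limit compound 3 lies. On these data alone, whether a simple amine or a urea on this carbon would keep the low numbers also remains open.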